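Fluoro to trifluoromethyl on the pendant phenyl of compound 3

The source may hold more compounds than are shown below. What is called first, only, known or untested is meant among the compounds shown, and "the series" means these compounds.

Compound 1 `COc1ccc(-c2ccnc(C(=O)Nc3ccc(Oc4ccnc5[nH]ccc45)cc3)n2)cc1` is measured in a functional assay on A549 cells (Homo sapiens) for cytotoxicity, read by MTT assay, with a stated time of 72 h; a higher number here means a weaker inhibitor, a lower number a stronger inhibitor; in this assay compound 1 gives 13300 nM. Compound 2 `COc1ccc(-c2cc(C(=O)Nc3ccc(Oc4ccnc5[nH]ccc45)cc3)ncn2)cc1` gives 4410 nM. Compound 3 `O=C(Nc1ccc(Oc2ccnc3[nH]ccc23)cc1)c1cc(-c2ccc(F)cc2)ncn1` gives 13000 nM, the second highest of the three numbers. The step of a 2.9-fold higher number from compound 2 to compound 3 (0.47 log units; beyond the scatter) is beyond the scatter, whereas the values of compound 3 and compound 1 lie within the scatter of each other.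

Compound 4 `O=C(Nc1ccc(Oc2ccnc3[nH]ccc23)cc1)c1cc(-c2ccc(C(F)(F)F)cc2)ncn1` differs from compound 3 by trifluoromethyl in place of fluoro on an aromatic carbon, that is, 4-fluorophenyl becomes 4-(trifluoromethyl)phenyl, the new group sitting para to a large group. Among the compounds with values here, no measured step involves a trifluoromethyl group. Within the data shown here, the only step at this position is a 2.9-fold higher number from compound 2 to compound 3 (0.47 log units; beyond the scatter), which was modest and concerned a different exchange, methoxy to fluoro. On this basis no step beyond the scatter is expected for compound 4 in this assay. The expected change is the step of a 1.1-fold lower number from compound 3 to compound 4 (0.03 log units; within the scatter). Compound 4 is estimated at 12000 nM, with a range from 4000 nM to 40000 nM.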

Compound 4, half-maximal inhibitory concentration: 9380 nM
The estimate for compound 4 lay 1.3-fold (0.11 log units) above the measured number; low and high end bracket the measured number.
By their numbers in this assay, from the lowest: compound 2; then compounds 4, 3 and 1 (each within the scatter of the next).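

Trifluoromethyl in place of fluoro on the pendant phenyl leaves the two compounds within the scatter in this assay (a 1.4-fold lower number from compound 3 to compound 4 (0.14 log units; within the scatter)), so this assay does not tell these two groups apart despite the added heavy atoms. Replacing methoxy with trifluoromethyl gives a modest step beyond the scatter (a 2.1-fold higher number from compound 2 to compound 4 (0.33 log units; beyond the scatter)), a second exchange away from methoxy that reads the same way as the step to fluoro (a 2.9-fold higher number from compound 2 to compound 3 (0.47 log units; beyond the scatter)), leaving compound 2 with the lowest number of the three compounds sharing this core. No data at hand explain why methoxy stands apart.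

On these data alone, whether an amine, a carboxylic acid or a longer chain at this place would read like methoxy or like fluoro and trifluoromethyl stays open. Also open, as far as these compounds go, is whether fluoro or trifluoromethyl would read the same on the core of compound 1.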